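The compounds below may be only part of what the source reports. "The series", "measured", "known", "first", "only" and "open" are said of these compounds alone.

Compound 1 `CN(O)C(=O)c1cc2ccn(Cc3ccc(F)cc3)c2cn1`: 135000 nM
Compound 2 `CN(O)C(=O)c1cc2c(CO)cn(Cc3ccc(F)cc3)c2cn1`: > 266000 nM
Compound 3 `COCc1cn(Cc2ccc(F)cc2)c2cnc(C(=O)N(C)O)cc12`: 266000 nM

In an ADME assay on CEM-SS cells (Homo sapiens) for cytotoxicity, read by XTT assay (a lower number here means that less compound is tolerated, a higher number that more compound is tolerated), compound 3 gives 266000 nM and compound 1 gives 135000 nM, two values within the scatter of each other. Compound 2 gives > 266000 nM, which is a limit and not a number.

Compound 4 `CN(O)C(=O)c1cc2c(C(=O)N3CCC[C@@H]3CO)cn(Cc3ccc(F)cc3)c2cn1` carries (2-(hydroxymethyl)pyrrolidin-1-yl)carbonyl in place of the methoxymethyl of compound 3, on an aromatic carbon of the five-membered aromatic ring: (2-(hydroxymethyl)pyrrolidin-1-yl)carbonyl in place of methoxymethyl on an aromatic carbon.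

Two measured steps change this same carbon: an at least 1.9-fold higher number from compound 1 to compound 2 (0.29 log units; that floor lies within the scatter), and a 2.0-fold higher number from compound 1 to compound 3 (0.29 log units; within the scatter). Neither goes beyond the scatter. The third, a number no higher from compound 2 to compound 3 (the limit leaves the size open), leaves its size open. Among the measured compounds shown here, no measured compound carries a group like the incoming one, so the range must stay wide.

On the evidence of a 2.0-fold higher number from compound 1 to compound 3 (0.29 log units; within the scatter), no step beyond the scatter is expected in this assay, in either direction. The expected change is a 1.2-fold lower number from compound 3 to compound 4 (0.08 log units; within the scatter). Compound 4 is estimated at 220000 nM, with an expected range of 90000 nM to 400000 nM.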

Compound 4, half-maximal cytotoxic concentration: > 32000 nM
Compound 4: a limit, no number; the forecaster's own chance of this, stated with the estimate: 50%; the middle value does not contradict the limit.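

In this assay compound 4 gives > 32000 nM, which is a limit and not a number. Among the compounds shown here, no step to compound 4 from compound 1, compound 2 or compound 3 can be read. The compounds shown leave open whether (2-(hydroxymethyl)pyrrolidin-1-yl)carbonyl on this aromatic carbon changes how much compound is tolerated, and by how much.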